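A few compounds are considered here, and "the series" means these few. Any claim that something is new, unique, unknown or untested is made for them only; others in the source may bear on it.

Compound 2 `CN(C)CCn1cnnc1-c1cc(Oc2ccc(NC(=O)N/N=C/c3cc(Br)c(O)c(Br)c3)cc2F)ccn1` was tested in a functional assay on NCI-H460 cells (Homo sapiens) for cytotoxicity, read by MTT assay, with a stated time of 72 h (a lower number here means a stronger inhibitor, a higher number a weaker inhibitor), where compound 2 gives 3760 nM. Among the two numbers known so far that is the highest, and its nearest neighbour is compound 1 `COc1ccc(OC)c(/C=N/NC(=O)Nc2ccc(Oc3ccnc(-c4nncn4CCN(C)C)c3)c(F)c2)c1`, which in this assay gives 2930 nM. The step of a 1.3-fold higher number from compound 1 to compound 2 (0.11 log units; within the scatter) exchanged one aromatic group for another on the carbon with a double bond to nitrogen and left the number essentially where it was. Compound 3 `CN(C)CCn1cnnc1-c1cc(Oc2ccc(NC(=O)N/N=C/c3cccc(O)c3)cc2F)ccn1` has not yet been measured in this assay. It differs from compound 2 at that same place: 3-hydroxyphenyl in place of 3,5-dibromo-4-hydroxyphenyl on a carbon with a double bond to nitrogen. Within the data shown here, the only measured step that bears on this change is the one from compound 1 to compound 2, and that step stayed within the scatter. A step of a 1.1-fold lower number from compound 2 to compound 3 (0.03 log units; within the scatter) is therefore expected, with no clear direction beyond the scatter. Compound 3 is estimated at 3500 nM, with a range from 1500 nM to 8500 nM.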

Compound 3, half-maximal inhibitory concentration: 780 nM
For compound 3 the middle estimate is 4.5-fold (0.65 log units) above the measured one; the whole stated range lies above it.
By their numbers in this assay, from the lowest: compound 3; then compounds 1 and 2 (each within the scatter of the next).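

This position is not indifferent to the aromatic group it carries in this assay, although the earlier pair gave no sign of that. Exchanging 3,5-dibromo-4-hydroxyphenyl for 3-hydroxyphenyl gives a 4.8-fold lower number from compound 2 to compound 3 (0.68 log units; beyond the scatter), and exchanging 2,5-dimethoxyphenyl for the same group gives a 3.8-fold lower number from compound 1 to compound 3 (0.57 log units; beyond the scatter), so compound 3 has the lowest number of the three, while the two larger groups remain within the scatter of each other. A hydroxyl group alone does not set the number, since compound 2 also carries one.

Nothing measured here explains the difference. Going by these compounds, it remains open whether the lower number depends on the hydroxyl group of 3-hydroxyphenyl or would also appear with a plain phenyl, a methoxyphenyl or an aminophenyl at this position.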